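This account rests on a few compounds, and the source may have more. Where it says the series, first, only, none or still open, it means among the compounds named here.

Compound 2 `COc1cc(/C=C/C(=O)OCCc2cccc(C)c2)cc(OC)c1O` is measured in an assay on PMNL cells for inhibition of Polyunsaturated fatty acid 5-lipoxygenase (Homo sapiens), read by HPLC, with stated times of 5 min and 15 min (a higher number here means a weaker inhibitor, a lower number a stronger inhibitor), at 200 nM. It stands level with compound 1 `COc1cc(/C=C/C(=O)OCCc2cccc(C(F)(F)F)c2)cc(OC)c1O`, which in this assay gives 200 nM; the step of no change at the digits printed from compound 1 to compound 2 (within the scatter) is within the scatter. Compound 3 `CCCOC(=O)/C=C/c1cc(OC)c(O)c(OC)c1` has not yet been measured in this assay. The change from compound 2 to compound 3 is methyl in place of 3-methylphenyl on a saturated chain carbon, two bonds along the chain from an oxygen next to a carbonyl group. Among the measured compounds shown here, no measured step removes the aromatic ring from the ester side chain; the only step, from compound 1 to compound 2, exchanges one group on that ring and shows no change, so it bears only weakly here. Compound 3 is therefore expected at 300 nM, between 100 nM and 1000 nM, the expected step of a 1.5-fold higher number from compound 2 to compound 3 (0.18 log units; within the scatter) being small.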

Compound 3, half-maximal inhibitory concentration: 710 nM
Compound 3: the middle estimate sits 2.4-fold (0.37 log units) below what was measured, and the stated range covers the measured number.
By their numbers in this assay, from the lowest: compounds 1 and 2 (each within the scatter of the next); then compound 3.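

Putting methyl in place of 3-methylphenyl at this place gives a 3.6-fold higher number from compound 2 to compound 3 (0.55 log units; beyond the scatter) in this assay, the first change shown to move the number beyond the scatter. The step is modest, so inhibition in the nanomolar range does not depend on the aromatic ring in the ester side chain, although the ring does contribute to the lower number. Nothing available explains this difference.

The compounds shown leave open how a longer chain or an amine at this place would read. They also leave open whether an unsubstituted phenyl ring would match compound 2.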